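The source may hold more compounds than are shown below. What is called first, only, known or untested is meant among the compounds shown, and "the series" means these compounds.

Measured in a functional assay on SK-MEL-5 cells (Homo sapiens) for cytotoxicity; a lower number here means that less compound is needed, a higher number that more compound is needed for the effect:
- Compound 1 (`COc1cc(/C=C\c2ccc(C(C)C)cc2)cc(OC)c1OC`) : 4.7 uM
- Compound 2 (`CCOc1ccc(/C=C\c2cc(OC)c(OC)c(OC)c2)cc1`) : 2.5 uM

Compound 2 stands level with compound 1, as the two numbers lie within the scatter of each other. Compound 3 (`COc1cc(/C=C\c2ccc(SC)cc2)cc(OC)c1OC`) has methylsulfanyl in place of ethoxy on an aromatic carbon, para to a large group: methylsulfanyl in place of ethoxy on an aromatic carbon. Within the data shown here, the only measured step that bears on this also exchanges a group on an aromatic carbon, and it is small: a 1.9-fold lower number from compound 1 to compound 2 (0.27 log units; within the scatter). No step beyond the scatter is therefore expected in this assay, though a single step is thin evidence. The estimated step is a 1.2-fold higher number from compound 2 to compound 3 (0.08 log units; within the scatter). For compound 3 the expected value is 3 uM, with an estimated range from 1 uM to 9 uM.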

Compound 3, concentration for half-maximal effect: 4 uM
Beside the measured number, compound 3's estimate is 1.3-fold (0.12 log units) below it; the range from low to high includes it.
By their numbers in this assay, from the lowest: compounds 2, 3 and 1 (each within the scatter of the next).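

In this assay, the position para to a large group now holds three different groups, and their numbers stay level: there is a 1.6-fold higher number from compound 2 to compound 3 (0.20 log units; within the scatter) and a 1.2-fold lower number from compound 1 to compound 3 (0.07 log units; within the scatter). Exchanging ethoxy or isopropyl for methylsulfanyl therefore makes no clear difference here, which is a finding about these three groups only. No measurement available here explains why the three read alike. Still open, on these data alone, is whether an amine or a carboxylic acid at this position would leave the number unchanged, and whether a longer chain would do so.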